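The source may hold more compounds than are shown below. What is called first, only, known or untested is meant among the compounds shown, and "the series" means these compounds.

The series shares one core, seen in compound 1 `Cc1ccc2nc(N3CCCc4cc(F)ccc4C3)cc(NCCN)c2c1`, compound 2 `Cc1ccc2nc(N3CCCc4ccc(F)cc4C3)cc(NC(C)CN)c2c1` and the not yet tested compound 3 `Cc1ccc2nc(N3CCCc4ccc(F)cc4C3)cc(NC3(CN)COC3)c2c1`. In an ADME assay on HEp-2 cells (Homo sapiens) for cytotoxicity, read by CCK-8 assay, with a stated time of 5 days (a lower number here means that less compound is tolerated, a higher number that more compound is tolerated), compound 1 reaches only a limit of the assay, > 3200 nM, and this limit of > 3200 nM in this assay, at which 1 of the 2 values shown sits, is all that is known of it. In this assay, among the measured compounds shown here, compound 2 gives 25000 nM; this is the only actual number in the set, so compound 2 stands alone as the one point of reference. Compound 3 is derived from compound 2 by the change (3-(aminomethyl)oxetan-3-yl in place of 1-(aminomethyl)ethyl on a nitrogen on an aromatic ring). For the measured compounds named here, no measured pair shows what such a change does here, so the expectation for the step of a 1.2-fold higher number from compound 2 to compound 3 (0.08 log units; within the scatter) is that it stays within the usual scatter, with no direction claimed. On that basis compound 3 is estimated to give 30000 nM in this assay, with a likely range from 12000 nM to 80000 nM.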

Compound 3, half-maximal cytotoxic concentration: 86000 nM
Compound 3: middle estimate off by 2.9-fold (0.46 log units), on the low side, and the stated range ends below it.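

In this assay, putting 3-(aminomethyl)oxetan-3-yl in place of 1-(aminomethyl)ethyl on a nitrogen on an aromatic ring gives a 3.4-fold higher number from compound 2 to compound 3 (0.54 log units; beyond the scatter), so more compound is tolerated. Among the compounds shown here, this is the first measured pair, and it shows that a change at this position alone can move the tolerated concentration by more than the usual scatter. Nothing measured here accounts for the step.

On these data alone, compound 1 differs from compound 2 in more than one place and offers only a limit of the assay, so it adds no second comparison: the limit of > 3200 nM in this assay, at which 1 of the 3 values shown sits. It remains open whether the oxetane oxygen matters, which a cyclobutane ring carrying the same aminomethyl group would test, and whether a longer chain ending in an amine would behave like either group.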